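The compounds below may be only part of what the source reports. "The series", "measured", "known", "first", "only" and "open" are said of these compounds alone.

Compound 1, `CC(C(=O)NCc1ccc(C(C)(C)C)nc1OC1CCCC1)c1ccc(NS(C)(=O)=O)c(F)c1`: 1.5 nM
Compound 2, `CCCCSc1nc(C(C)(C)C)ccc1CNC(=O)C(C)c1ccc(NS(C)(=O)=O)c(F)c1`: 3.2 nM
Compound 3, `CC(C(=O)NCc1ccc(C(C)(C)C)cc1N1CCCCC1)c1ccc(NS(C)(=O)=O)c(F)c1`: 1.9 nM

In an assay on cells for antagonist activity at transient receptor potential cation channel subfamily V member 1 (Homo sapiens), read by FLIPR and calcium flux, with a stated time of 6 min (on this read-out lower numbers stand for stronger inhibition and higher numbers for weaker inhibition), compound 3 gives 1.9 nM, which stands second highest of the three numbers, though neither gap is more than scatter: compound 1 gives 1.5 nM and compound 2 gives 3.2 nM. Compound 4, `CC(C(=O)NCc1ccc(C(C)(C)C)cc1SC1CCCCC1)c1ccc(NS(C)(=O)=O)c(F)c1`, differs from compound 3 in one place: cyclohexylsulfanyl in place of piperidin-1-yl on an aromatic carbon. For the measured compounds named here, the one measured step that bears on this change is a 2.1-fold higher number from compound 1 to compound 2 (0.33 log units; beyond the scatter), where a butylsulfanyl group took the place of a cyclopentyloxy group on an aromatic carbon, and the number rose modestly. That step exchanges a ring-bearing group for a sulfanyl group, as the change from compound 3 to compound 4 does, so a small rise in this assay, or none beyond the scatter, is expected here. On that basis compound 4 is expected to give 2.6 nM, with a likely range from 1 nM to 7 nM, which would mean an estimated step of a 1.4-fold higher number from compound 3 to compound 4 (0.14 log units; within the scatter).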

Compound 4, inhibition constant: 7.4 nM
The estimate for compound 4 lay 2.8-fold (0.45 log units) below the measured number; measured number outside the range, above it.
By their numbers in this assay, from the lowest: compounds 1, 3 and 2 (each within the scatter of the next, the first and the last beyond it); then compound 4.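

In this assay, cyclohexylsulfanyl in place of piperidin-1-yl on this aromatic carbon, ortho to a large group and meta to a tert-butyl group, gives a 3.9-fold higher number from compound 3 to compound 4 (0.59 log units; beyond the scatter). The group here therefore affects the number even when both the leaving and the entering group hold a six-membered non-aromatic ring, one with a hetero atom and one of carbon only. With a 2.1-fold higher number from compound 1 to compound 2 (0.33 log units; beyond the scatter) on a different core, both listed steps that bring in a sulfanyl group go the same way, but no measurement shown accounts for this rise.

The compounds shown leave open whether the rise follows the sulfur link or the loss of the ring nitrogen. A cyclohexyloxy or cyclohexylamino group at this place would separate the two, and a butylsulfanyl group would test whether the ring matters on this core.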